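Notes on the step from compound 1 to compound 3

A few compounds are considered here, and "the series" means these few. Any claim that something is new, unique, unknown or untested is made for them only; others in the source may bear on it.

Measured so far in a functional assay on MCF7 cells (Homo sapiens) for antiproliferative activity, read by luminescence, with a stated time of 24 h (a lower number here means a stronger inhibitor, a higher number a weaker inhibitor), as follows
- compound 1 `Cc1c(C)c2c(c(C)c1OC(=O)CCCC[C@@H]1SC[C@@H]3NC(=O)N[C@@H]31)CCC(C)(COc1ccc(CC3SC(=O)NC3=O)cc1)O2` gives 15900 nM in this series
- compound 2 `Cc1cc(C)c2c(c1C)OC(C)(COc1ccc(CC3SC(=O)NC3=O)cc1)CC2` gives 20000 nM in this series

Compound 1 and compound 2 lie within the scatter of each other, so these two numbers give no ranking. Compound 3 `Cc1c(C)c2c(c(C)c1OC(=O)CCCC[C@@H]1SC[C@@H]3NC(=O)N[C@@H]31)CCC(C)(COc1ccc(/C=C3\SC(=O)NC3=O)cc1)O2` is still to be measured in this assay. It departs from compound 1 in one place, on an aromatic carbon of a six-membered aromatic ring of carbon only, para to a large group. There the (2,4-dioxo-1,3-thiazolidin-5-yl)methyl leaves and a group with no common name enters (a group of 8 heavy atoms (4 carbon, 1 nitrogen, 2 oxygen, 1 sulfur; one five-membered non-aromatic ring with 2 hetero atoms) in place of a group of 8 heavy atoms (4 carbon, 1 nitrogen, 2 oxygen, 1 sulfur; one five-membered non-aromatic ring with 2 hetero atoms), on an aromatic carbon). Within the data shown here, no measured pair in this set shows what such a change does, so the expectation rests only on the level of compound 1 at 15900 nM and carries a wide range. The estimated move is a 1.3-fold lower number from compound 1 to compound 3 (0.12 log units; within the scatter), a small shift toward a lower number that is expected to stay within the scatter. For compound 3 the expected value is 12000 nM, with an estimated range of 5000 nM to 28000 nM for the measurement.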

Compound 3, half-maximal inhibitory concentration: 11200 nM
The estimate for compound 3 lay 1.1-fold (0.03 log units) above the measured number, and the stated range covers the measured number.
By their numbers in this assay, from the lowest: compounds 3, 1 and 2 (each within the scatter of the next).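

In this assay, the step at this place, on an aromatic carbon of a six-membered aromatic ring of carbon only, para to a large group, is a 1.4-fold lower number from compound 1 to compound 3 (0.15 log units; within the scatter). Among these compounds, this is the first step to test this position: the (2,4-dioxo-1,3-thiazolidin-5-yl)methyl and the group that enters have the same counts of heavy atoms, hydrogen-bond donors and hydrogen-bond acceptors, but the entering group has 3 double bonds outside aromatic rings rather than 2, and this exchange does not separate compound 1 from compound 3 in this read-out. No supporting data bear on why the step has this size.

On these data alone, it remains open whether a different group at this place, such as a carboxylic acid, an amine or a longer chain in place of the (2,4-dioxo-1,3-thiazolidin-5-yl)methyl, would give a step beyond the scatter. The compounds shown also leave open whether the same exchange, made on compound 2, would give a step of similar size in this assay.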